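Isopropyl for Methyl on the Aromatic Amine Nitrogen

The compounds below may be only part of what the source reports. "The series", "measured", "known", "first", "only" and "open" are said of these compounds alone.

Three measured compounds share one core and differ only in the amine on its aromatic ring. Compound 1 `CN(c1ccc2cc(NC(=O)CCc3ccc(C(F)(F)F)cc3)ccc2n1)C1CCCCC1` carries a cyclohexyl(methyl)amino group, compound 2 `O=C(CCc1ccc(C(F)(F)F)cc1)Nc1ccc2nc(N3CCCCC3)ccc2c1` a piperidin-1-yl, and compound 3 `CN(C)c1ccc2cc(NC(=O)CCc3ccc(C(F)(F)F)cc3)ccc2n1` a dimethylamino. In an assay on isolated protein for displacement of a labelled ligand from melanin-concentrating hormone receptor 1 (Homo sapiens) (a lower number here means a stronger inhibitor, a higher number a weaker inhibitor), compound 1 gives 18 nM, compound 2 gives 12 nM and compound 3 gives 13 nM. Compound 3 sits second highest of the three numbers, yet every step among them stays within the scatter: a 1.5-fold lower number from compound 1 to compound 2 (0.18 log units; within the scatter), a 1.4-fold lower number from compound 1 to compound 3 (0.14 log units; within the scatter) and a 1.1-fold higher number from compound 2 to compound 3 (0.03 log units; within the scatter). Compound 4 `CC(C)N(C)c1ccc2cc(NC(=O)CCc3ccc(C(F)(F)F)cc3)ccc2n1` has not yet been measured. Its change from compound 3: isopropyl in place of methyl on a nitrogen on an aromatic ring. The step that bears most on it is a 1.4-fold lower number from compound 1 to compound 3 (0.14 log units; within the scatter), where cyclohexyl on that same nitrogen moved the number only within the scatter; the other two steps were equally small. A shift beyond the scatter is therefore not expected in this assay. The expected step is no change at the digits printed from compound 3 to compound 4 (within the scatter). Compound 4 is estimated at 13 nM, with a range from 6 nM to 30 nM.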

Compound 4, half-maximal inhibitory concentration: 2 nM
Compound 4: middle estimate off by 6.5-fold (0.81 log units), on the high side; measured number outside the range, below it.
By their numbers in this assay, from the lowest: compound 4; then compounds 2, 3 and 1 (each within the scatter of the next).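

In this assay, the amine on the aromatic ring had seemed to tolerate any change, but this result shows that it does not: a 6.5-fold lower number from compound 3 to compound 4 (0.81 log units; beyond the scatter), with only methyl replaced by isopropyl on the nitrogen. Isopropyl(methyl)amino also stands clear of the other two amines, with a 6.0-fold lower number from compound 2 to compound 4 (0.78 log units; beyond the scatter) and a 9.0-fold lower number from compound 1 to compound 4 (0.95 log units; beyond the scatter), so the numbers do not simply follow group size: the smaller methyl and the larger cyclohexyl lie within the scatter of each other, and isopropyl alone stands apart. Nothing given here explains this gain.

Whether it needs the branched shape of isopropyl stays open, since ethyl, cyclopropyl and tert-butyl on that nitrogen are absent from the compounds shown. As far as these compounds go, the role of the remaining methyl also stays open, and isopropylamino or diisopropylamino would test it.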